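The compounds below may be only part of what the source reports. "The series", "measured", "known", "first", "only" and "open" are said of these compounds alone.

Measured in a physicochemical assay for lipophilicity, read by LC-MS, in phosphate buffer, measured as octanol-water partition, with a stated time of 30 min, at pH 7.4, tested at 200 mM; on this read-out higher numbers stand for higher lipophilicity and lower numbers for lower lipophilicity:
- Compound 1 `Cn1c(COc2cccc(C(=O)O)c2)nc2ccc(Oc3ncccc3Cl)cc21`: 1.1
- Compound 2 `Cc1cccc(Oc2ccc3nc(COc4cccc(C(=O)O)c4)n(C)c3c2)n1`: 0.8
- Compound 3 `Cn1c(COc2cccc(C(=O)O)c2)nc2ccc(Oc3ccc(F)cn3)cc21`: 0.6

Compound 3 stands at 0.6, within the scatter of compound 2 and clearly apart from compound 1. Compound 4 `Cc1ccc(C)c(Oc2ccc3nc(COc4cccc(C(=O)O)c4)n(C)c3c2)n1` carries 3,6-dimethylpyridin-2-yl in place of 5-fluoropyridin-2-yl on an oxygen on an aromatic ring. Among the compounds with values here, no measured step makes this exact change. The closest evidence is a number 0.50 log units lower from compound 1 to compound 3 (beyond the scatter) and a number 0.20 log units lower from compound 2 to compound 3 (within the scatter), since both replace a substituted pyridinyl group with 5-fluoropyridin-2-yl. Reversing that kind of change suggests an upward move about as large as the larger of these steps. The expected step is a number 0.50 log units higher from compound 3 to compound 4 (beyond the scatter). Compound 4 is estimated at 1.1, with an expected range of 0.8 to 1.5.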

Compound 4, distribution coefficient: 1.4
For compound 4 the middle estimate is 0.30 log units below the measured one; low and high end bracket the measured number.
By their numbers in this assay, from the lowest: compounds 3, 2, 1 and 4 (each within the scatter of the next, the first and the last beyond it).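

Methyl in place of hydrogen on an aromatic carbon alone gives a number 0.60 log units higher from compound 2 to compound 4 (beyond the scatter) in this assay and so shows that a second methyl on 6-methylpyridin-2-yl still moves this read-out upward. The full exchange gives a number 0.80 log units higher from compound 3 to compound 4 (beyond the scatter) and is the largest step seen at this place, whereas a number 0.30 log units higher from compound 1 to compound 4 (within the scatter) leaves 3,6-dimethylpyridin-2-yl and 3-chloropyridin-2-yl unseparated. No measurement shown here explains these shifts.

As far as these compounds go, whether a methoxy group or an amine in place of the added methyl would move the number the same way stays open.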